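The source may report more compounds than this note shows. Statements on the series, on what has been measured and on what is new or still open speak of the compounds shown alone.

Three members of the series have been run in a functional assay on the whole organism (strain albino) for inhibition, with Rattus norvegicus as the target, read by paw edema, with stated times of 1 h and 3 h, at a dose of 25 mg/kg by the oral route; a lower number here means less inhibition, a higher number more inhibition at the dose given (going by the name of the read-out); all share one core and differ only in the aryl group on the double-bonded chain carbon bound to an aromatic carbon. Compound 1 `COc1ccc(/C=c2/sc3n(c2=O)C(c2ccc(Br)cc2)C(C(=O)Nc2ccc(F)cc2)=C(C)N=3)cc1OC` gives 8% in this assay. Compound 2 `CC1=C(C(=O)Nc2ccc(F)cc2)C(c2ccc(Br)cc2)n2c(s/c(=C/c3ccc(Cl)cc3Cl)c2=O)=N1` gives 14%. Compound 3 `CC1=C(C(=O)Nc2ccc(F)cc2)C(c2ccc(Br)cc2)n2c(s/c(=C/c3ccc(Cl)cc3)c2=O)=N1` gives 25%. The step of a number 6 percentage points higher from compound 1 to compound 2 (within the scatter) stays within the scatter, whereas a number 17 percentage points higher from compound 1 to compound 3 (beyond the scatter) and a number 11 percentage points higher from compound 2 to compound 3 (beyond the scatter) both run beyond it. Compound 3 therefore stands highest of the three, its steps to compound 2 and to compound 1 both beyond the scatter.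

Compound 4 `CC1=C(C(=O)Nc2ccc(F)cc2)C(c2ccc(Br)cc2)n2c(s/c(=C/c3ccc(C)cc3)c2=O)=N1` awaits measurement. Relative to compound 3 the change is methyl in place of chloro on an aromatic carbon. For the measured compounds named here, no measured step swaps chloro for methyl. The nearest guides are a number 11 percentage points higher from compound 2 to compound 3 (beyond the scatter), where a hydrogen took the place of a chloro, and a number 17 percentage points higher from compound 1 to compound 3 (beyond the scatter), where a 4-chlorophenyl took the place of a 3,4-dimethoxyphenyl. Both steps moved the read-out modestly, but neither reaches a methyl, so in this assay only a small step from compound 3 is expected, direction open. Compound 4 is expected to give about 20%, within 8% to 32%. The expected step is a number 5 percentage points lower from compound 3 to compound 4 (within the scatter), likely within the scatter.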

Compound 4, a percentage reported as inhibition, in the whole organism at one dose (the size of the read-out at that dose, not a potency): 11%
Beside the measured number, compound 4's estimate is 9 percentage points above it; the range from low to high includes it.
By their numbers in this assay, from the lowest: compounds 1, 4 and 2 (each within the scatter of the next); then compound 3.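

In this assay the swap of chloro for methyl on an aromatic carbon, para to a large group, gives a number 14 percentage points lower from compound 3 to compound 4 (beyond the scatter) and so shows that exchanging one heavy atom for one heavy atom can move the read-out at this position, even with no hydrogen-bond donor, hydrogen-bond acceptor or net charge on either group. With a number 3 percentage points lower from compound 2 to compound 4 (within the scatter) and a number 3 percentage points higher from compound 1 to compound 4 (within the scatter) in view, 4-methylphenyl cannot be told apart from 2,4-dichlorophenyl or 3,4-dimethoxyphenyl, and 4-chlorophenyl alone stands apart among the four aryl groups, with its steps to all three others beyond the scatter. No measurement at hand accounts for the gap between chloro and methyl at this carbon.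

Still open, on these data alone, is whether this read-out depends on chloro itself or would hold for another halogen, such as fluoro or bromo, at the same place on the ring. A hydroxyl, an amine or a carboxylic acid there would show whether any other group matches 4-chlorophenyl or exceeds it, and the single dose leaves potency across the series unresolved.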